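Bromo in place of carboxy: expected step

A few compounds are considered here, and "the series" means these few. Any claim that something is new, unique, unknown or untested is made for them only; others in the source may bear on it.

Measured in an ADME assay on J744 cells (Mus musculus) for cytotoxicity, read by MTT assay, with a stated time of 48 h; on this read-out higher numbers stand for weaker inhibition and lower numbers for stronger inhibition:
- compound 1 `Cc1c(C(=O)N/N=C/c2ccc(N(C)C)cc2)no[n+]1[O-]`: 129000 nM
- compound 2 `O=C(O)c1ccc(/C=N/NC(=O)c2c(-c3ccccc3)no[n+]2[O-])cc1`: > 300000 nM (a limit)
- compound 3 `Cc1c(C(=O)N/N=C/c2ccc(C(=O)O)cc2)no[n+]1[O-]`: > 400000 nM (a limit)

Compound 3 stands at > 400000 nM, which is a limit and not a number. Compound 2 gives > 300000 nM, which is also a limit. Among the compounds with values here, compound 1, at 129000 nM, is the only true number in the set.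

The next compound, compound 4 `Cc1c(C(=O)N/N=C/c2ccc(Br)cc2)no[n+]1[O-]`, carries bromo in place of carboxy on an aromatic carbon. The change lies on a six-membered aromatic ring of carbon only, para to a large group.

Within the data shown here, only one measured step involves carboxy on an aromatic carbon, with carboxy in place of dimethylamino: an at least 3.1-fold higher number from compound 1 to compound 3 (0.49 log units; beyond the scatter). That step lies beyond the scatter. Among the measured compounds shown here, no compound with bromo has been measured yet, so this single step is the only guide, and it supports a direction more firmly than a size.

In this assay, a move to a lower number, meaning stronger inhibition, is expected once carboxy leaves. The expected change is an at least 2.6-fold lower number from compound 3 to compound 4 (0.42 log units; beyond the scatter). For compound 4 the estimate is 150000 nM, with an expected range from 60000 nM to 400000 nM.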

Compound 4, half-maximal inhibitory concentration: 162000 nM
Compound 4: the middle estimate sits 1.1-fold (0.03 log units) below what was measured; measured number inside the range.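

In this assay, bromo in place of carboxy on an aromatic carbon of the six-membered ring gives an at least 2.4-fold lower number from compound 3 to compound 4 (0.39 log units; beyond the scatter), so the earlier shift seen on leaving dimethylamino for carboxy is now matched from the other side by a second group. Bromo in place of dimethylamino gives a 1.3-fold higher number from compound 1 to compound 4 (0.10 log units; within the scatter), so these two groups cannot be told apart at this place, and among the three groups on this methyl-bearing core, only carboxy stands apart from the others. Compound 3 is held only as a limit, so the full size of its gap to the other two stays unknown: the limit of > 400000 nM in this assay, at which 1 of the 4 values shown sits.

Going by these compounds, it remains open whether the separation belongs to carboxy alone or extends to related groups at this place, such as a methyl ester or a primary amide, and whether a second halogen such as chloro would read like bromo. Compound 2 carries carboxy on a phenyl-bearing core, and no partner with bromo or dimethylamino on that core is among these compounds, so the pattern cannot yet be carried over to it.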